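A few compounds are considered here, and "the series" means these few. Any claim that something is new, unique, unknown or untested is made for them only; others in the source may bear on it.

Compound 1 `COc1cc(-c2cc(/C=C/C(=O)c3ccc(N)cc3)[nH]n2)cc(OC)c1OC`: 94%
Compound 2 `COc1cc(-c2cc(/C=C/C(=O)c3ccc(Cl)c(Cl)c3)[nH]n2)cc(OC)c1OC`: 95%
Compound 3 `COc1ccc(-c2cc(/C=C/C(=O)c3cc(OC)c(OC)c(OC)c3)[nH]n2)cc1OC`: 92%

In a functional assay on U-251 cells (Homo sapiens) for cytotoxicity, read by sulforhodamine B assay, with a stated time of 48 h, tested at 0.1 uM (a higher number here means a weaker effect of the compound at the concentration tested, a lower number a stronger effect), all three measured compounds give numbers that lie within the usual scatter of one another, so none of them is set apart. Compound 2 has the largest of the three numbers, but compound 1 is within the scatter of it and compound 3, the furthest away, is within the scatter as well. Compound 4 `COc1cc(-c2cc(/C=C/C(=O)c3ccc(F)c(F)c3)[nH]n2)cc(OC)c1OC` is the next compound to be measured; compared with compound 2 it carries 3,4-difluorophenyl in place of 3,4-dichlorophenyl on a carbonyl carbon. Within the data shown here, the one measured step at the same place, an exchange of the group on the carbonyl carbon, is a number 1 percentage points higher from compound 1 to compound 2 (within the scatter), and it stayed within the scatter. Among the measured compounds shown here, with no other steps of this kind to draw on, the change to compound 4 is expected to leave the number essentially where compound 2 stands. This means an expected no change at the digits printed from compound 2 to compound 4 (within the scatter). Compound 4 is therefore estimated to give 95%, with a range from 88% to 100%.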

Compound 4, a percentage reported as activity, at one concentration (the size of the read-out at that concentration, not a potency): 96%
The estimate for compound 4 lay 1 percentage points below the measured number, within the range that was stated.
By their numbers in this assay, from the lowest: compounds 3, 1, 2 and 4 (each within the scatter of the next).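

In this assay, the group on the carbonyl carbon can now be compared across three cases: 3,4-difluorophenyl in place of 3,4-dichlorophenyl gives a number 1 percentage points higher from compound 2 to compound 4 (within the scatter) and 3,4-difluorophenyl in place of 4-aminophenyl gives a number 2 percentage points higher from compound 1 to compound 4 (within the scatter) as its result. The exchange of one halogen for another on this ring therefore joins the earlier exchange in staying within the scatter, so 4-aminophenyl, 3,4-dichlorophenyl and 3,4-difluorophenyl cannot be told apart at this place at the single concentration tested. Nothing available here offers an explanation for this result.

Still open, as far as these compounds go, is whether any group on this carbonyl carbon can move the number beyond the scatter, for example a phenyl ring carrying a carboxylic acid, or a longer alkyl chain in place of the ring. Also open, from the compounds shown here alone, is whether these three groups would separate at other concentrations.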